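The source may hold more compounds than are shown below. What is called first, only, known or untested is meant among the compounds shown, and "the series" means these compounds.

Compound 2, with the structure `Cc1nc2cc(C(=O)NCc3ccc(F)cc3O)nn2c(-c2cc(F)c3c(c2C)CCCO3)c1[C@H](OC(C)(C)C)C(=O)O`, was examined in an ADME assay on MT2 cells (Homo sapiens) for cytotoxicity; a higher number here means that more compound is tolerated, a lower number that less compound is tolerated. In this assay compound 2 gives > 40000 nM, which is a limit of the assay and not a measured number. Its neighbour compound 1, with the structure `Cc1cc(CNC(=O)c2cc3nc(C)c([C@H](OC(C)(C)C)C(=O)O)c(-c4cc(F)c5c(c4C)CCCO5)n3n2)ccc1F`, was run in the same assay. Compound 1 gives > 40000 nM, again a limit rather than a number. Among the compounds with values here, the single step between measured compounds, a step that the two limits leave unreadable from compound 1 to compound 2, cannot be sized because of the limit of > 40000 nM in this assay, at which 2 of the 2 values shown sit.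

The next compound, compound 3, has the structure `Cc1nc2cc(C(=O)NCc3ccc(F)cc3-n3cncn3)nn2c(-c2cc(F)c3c(c2C)CCCO3)c1[C@H](OC(C)(C)C)C(=O)O`. It differs from compound 2 by 1H-1,2,4-triazol-1-yl in place of hydroxy on an aromatic carbon. Within the data shown here, no measured step covers a change of this kind, so the only guide is that both measured compounds sit at the limit of the assay. The step from compound 2 to compound 3 is therefore expected to be a number no higher from compound 2 to compound 3 (the limit leaves the size open), with no direction that can be read from the data. Compound 3 is estimated to give 40000 nM in this assay, within a range from 15000 nM to 40000 nM, and the result is most likely to be reported again as a limit.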

Compound 3, half-maximal cytotoxic concentration: > 40000 nM
Compound 3 ended at the assay's limit; the forecaster's own chance of this, stated with the estimate: 80%; the middle value lies on the limit itself.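

Compound 3 gives > 40000 nM in this assay, which is a limit and not a number. No step between compound 1, compound 2 and compound 3 can be read, because each result stops at the same ceiling: the limit of > 40000 nM in this assay, at which 3 of the 3 values shown sit.

The compounds shown leave open how much of each is actually tolerated, and whether 1H-1,2,4-triazol-1-yl in place of hydroxy changes that at all.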